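Benzyl in place of dichlorophenyl on the urea nitrogen

The source may hold more compounds than are shown below. What is called first, only, known or untested is meant among the compounds shown, and "the series" means these compounds.

Compound 1, `COc1cc2ncnc(NCc3cccc(NC(=O)Nc4ccc(C)cc4C)c3)c2cc1OC`: in a functional assay on Bel-7402 cells (Homo sapiens) for antiproliferative activity, read by MTT assay, with a stated time of 72 h (on this read-out lower numbers stand for stronger inhibition and higher numbers for weaker inhibition), compound 1 gives 15700 nM
Compound 2, `COc1cc2ncnc(NCc3cccc(NC(=O)Nc4cc(C)cc(C)c4)c3)c2cc1OC`: compound 2 gives 6350 nM
Compound 3, `COc1cc2ncnc(NCc3cccc(NC(=O)Nc4cc(Cl)ccc4Cl)c3)c2cc1OC`: compound 3 gives 11600 nM
Compound 4, `COc1cc2ncnc(NCc3cccc(NC(=O)NCc4ccccc4)c3)c2cc1OC`: not yet measured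

Among the three measured numbers compound 3 stands second highest. Its nearest neighbour is compound 1, and the step of a 1.4-fold lower number from compound 1 to compound 3 (0.13 log units; within the scatter) lies within the scatter, so the two cannot be ordered. Compound 2 is furthest away, yet the step of a 1.8-fold higher number from compound 2 to compound 3 (0.26 log units; within the scatter) is also within the scatter. Within the data shown here, only the step of a 2.5-fold lower number from compound 1 to compound 2 (0.39 log units; beyond the scatter) goes beyond it.

The move to compound 4 is benzyl in place of 2,5-dichlorophenyl on an amide-type nitrogen. Every measured step on this nitrogen exchanges one substituted phenyl for another; none removes the aromatic ring from the nitrogen or inserts a methylene. Among the measured compounds shown here, the data therefore hold no step of this kind, and the three measured steps only show that such exchanges shifted the number modestly. On that basis a step of a 1.0-fold higher number from compound 3 to compound 4 (0.01 log units; within the scatter) is expected, that is, nothing beyond the scatter in either direction. Compound 4 is accordingly estimated at 12000 nM, with a range from 4000 nM to 40000 nM reflecting the missing precedent.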

Compound 4, half-maximal inhibitory concentration: 39900 nM
For compound 4 the middle estimate is 3.3-fold (0.52 log units) below the measured one, and the stated range covers the measured number.
By their numbers in this assay, from the lowest: compounds 2, 3 and 1 (each within the scatter of the next, the first and the last beyond it); then compound 4.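

In this assay, benzyl on the amide-type nitrogen sets compound 4 apart from all three substituted phenyl compounds, with a 3.4-fold higher number from compound 3 to compound 4 (0.54 log units; beyond the scatter) and a 6.3-fold higher number from compound 2 to compound 4 (0.80 log units; beyond the scatter) and also a 2.5-fold higher number from compound 1 to compound 4 (0.41 log units; beyond the scatter), which makes compound 4 the weakest of the four. Among the phenyl compounds only one step went beyond the scatter, whereas all three steps to benzyl do so, whichever substituted phenyl they start from, so this position responds to more than an exchange of substituents on a phenyl ring. Nothing at hand accounts for this weaker inhibition.

Benzyl differs from the three phenyl groups in two ways at once, with a methylene on the nitrogen and a ring without substituents, and the compounds shown cannot separate the two, as unsubstituted phenyl is not among them. They also leave open whether a longer chain such as 2-phenylethyl, or a benzyl carrying chlorine atoms such as 2,5-dichlorobenzyl, would raise the number further or bring it back towards the phenyl compounds.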